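A few compounds are considered here, and "the series" means these few. Any claim that something is new, unique, unknown or untested is made for them only; others in the source may bear on it.

Compound 2 `O=c1c(CSC(=S)N2CCN(c3ccccc3)CC2)coc2ccccc12` gives 16700 nM in a functional assay on HEp-2 cells (Homo sapiens) for antiproliferative activity, read by MTT assay, with a stated time of 72 h (on this read-out higher numbers stand for weaker inhibition and lower numbers for stronger inhibition), and so stands at the highest of the three numbers measured. Compound 1 `Cc1ccc2c(=O)c(CSC(=S)N3CCCCC3)coc2c1` gives 900 nM in this assay, and compound 3 `O=c1c(CSC(=S)N2CCOCC2)coc2cc(Cl)ccc12` gives 900 nM in this assay; both sit well beyond the scatter from compound 2. Compound 4 `CN1CCN(C(=S)SCc2coc3ccccc3c2=O)CC1` differs from compound 2 in one place: methyl in place of phenyl on an amine nitrogen in a ring. Among the measured compounds shown here, no one-place step between measured compounds covers this change, so the direction rests on compound 1 with 900 nM and compound 3 with 900 nM, which carry smaller ring amines and lower numbers. A step from compound 2 to compound 4 toward a lower number, of moderate size, is therefore expected, namely a 3.3-fold lower number from compound 2 to compound 4 (0.52 log units; beyond the scatter). Compound 4 is estimated at 5000 nM in this assay, within 1500 nM to 16000 nM.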

Compound 4, half-maximal inhibitory concentration: 2400 nM
The estimate for compound 4 lay 2.1-fold (0.32 log units) above the measured number, within the range that was stated.
By their numbers in this assay, from the lowest: compounds 1 and 3 (each within the scatter of the next); then compound 4; then compound 2.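

In this assay, among the compounds shown here, this is the first one-place reading: on the amine nitrogen in the ring, methyl in place of phenyl gives a 7.0-fold lower number from compound 2 to compound 4 (0.84 log units; beyond the scatter). The read-out therefore responds to the group at this position, and the phenyl form lies on the side of weaker inhibition. No measured evidence bears on the cause of this step. Open, going by these compounds, is whether a hydrogen, an ethyl or a benzyl group on that nitrogen would continue the same direction. Also open, on these data alone, is whether the step follows the loss of the aromatic ring or the smaller group, which an acetyl or cyclohexyl group could begin to separate.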